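Acetyl for Ester: Expected Solubility of Compound 4

A few compounds are considered here, and "the series" means these few. Any claim that something is new, unique, unknown or untested is made for them only; others in the source may bear on it.

Compound 1 `CCOC(=O)c1ccc(Nc2ccnc(-c3cccnc3)n2)cc1` and compound 2 `CCOC(=O)c1cccc(Nc2ccnc(-c3cccnc3)n2)c1` are built from the same atoms joined differently; the difference between the two cores is not broken down here. In a physicochemical assay for solubility, in phosphate buffer (a lower number here means a less soluble compound, a higher number a more soluble compound), compound 1 gives 61000 nM and compound 2 gives 92000 nM. Compound 3 `CC(=O)c1ccc(Nc2ccnc(-c3cccnc3)n2)cc1` differs from compound 1 by methyl in place of ethoxy on a carbonyl carbon; in this assay compound 3 gives 98000 nM, which is a 1.6-fold higher number from compound 1 to compound 3 (0.21 log units; within the scatter). Compound 4 `CC(=O)c1cccc(Nc2ccnc(-c3cccnc3)n2)c1` carries the same change relative to compound 2, (methyl in place of ethoxy on a carbonyl carbon), at a place described in identical words. Since the measured step of a 1.6-fold higher number from compound 1 to compound 3 (0.21 log units; within the scatter) stays within the scatter, for compound 4 the expected step is about as small: a 1.4-fold higher number from compound 2 to compound 4 (0.15 log units; within the scatter). Compound 4 is therefore estimated at 130000 nM in this assay, with a likely range from 60000 nM to 280000 nM.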

Compound 4, solubility: 97000 nM
The estimate for compound 4 lay 1.3-fold (0.13 log units) above the measured number, within the range that was stated.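

In this assay, methyl in place of ethoxy on the carbonyl carbon gives a 1.1-fold higher number from compound 2 to compound 4 (0.02 log units; within the scatter), and the same change on the core of compound 1 gives a 1.6-fold higher number from compound 1 to compound 3 (0.21 log units; within the scatter). The change therefore carries across the two cores in one limited sense: on neither core does it give a step that can be told apart from the ordinary spread of repeat measurements. This does not show that the change moves the number at all, or that it moves the number by the same amount on both cores. Nothing shown gives a reason for either step. The compounds shown leave open what an amine or a longer chain on this carbonyl carbon would do to the number. They also leave open whether either group would behave alike on both cores.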